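Phenethyl in place of 4-ethylphenyl on a sulfur

The source may hold more compounds than are shown below. What is called first, only, known or untested is meant among the compounds shown, and "the series" means these compounds.

Compound 1 `Nc1ccccc1NC(=O)/C=C/c1ccc(CSc2cccc(F)c2)cc1`: 50.7%
Compound 2 `CCc1ccc(SCc2ccc(/C=C/C(=O)Nc3ccccc3N)cc2)cc1`: 60.7%
Compound 3 `CC(C)(C)c1ccc(SCc2ccc(C(=O)Nc3ccccc3N)cc2)cc1`: 38.6%

In a functional assay on A549 cells (Homo sapiens) for inhibition, read by CCK-8 assay, with a stated time of 72 h, tested at 2 uM (on this read-out lower numbers stand for less inhibition of growth and higher numbers for more inhibition of growth at the one concentration tested), compound 2 gives 60.7%. Its closest neighbour is compound 1 at 50.7%, and the two lie within the scatter of each other. Compound 3, at 38.6%, lies lower than compound 2, and that gap is beyond the scatter.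

The next compound to be tested is compound 4 `Nc1ccccc1NC(=O)/C=C/c1ccc(CSCCc2ccccc2)cc1`, which has phenethyl in place of 4-ethylphenyl on a sulfur. Within the data shown here, none of the measured compounds carries phenethyl, so no measured step covers this exact change. Among the measured compounds shown here, the nearest guide is the one measured step that alters the group on the sulfur, a number 10 percentage points higher from compound 1 to compound 2 (within the scatter). That single step stays within the scatter, and it gives only weak support for any direction. The expectation therefore rests on that modest step, with a wide range to allow for the untested group. In this assay the estimated change is a number 8.7 percentage points lower from compound 2 to compound 4 (within the scatter), a slight drop that is not expected to exceed the scatter. For compound 4 the estimated value is 52%, with an expected range from 33% to 70%.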

Compound 4, percent growth inhibition at one concentration: 45.7%
For compound 4 the middle estimate is 6.3 percentage points above the measured one; measured number inside the range.
By their numbers in this assay, from the lowest: compounds 3, 4, 1 and 2 (each within the scatter of the next, the first and the last beyond it).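

In this assay, replacing 4-ethylphenyl with phenethyl on the sulfur gives a number 15 percentage points lower from compound 2 to compound 4 (beyond the scatter). The two groups have the same count of carbon atoms and the same kind of ring, so this step shows that a rearrangement of those atoms alone can produce a difference beyond the scatter, which the earlier step at this position did not show. Among these compounds, replacing 3-fluorophenyl with phenethyl gives a number 5 percentage points lower from compound 1 to compound 4 (within the scatter), so compound 1 cannot be separated from compound 2 or compound 4, and only the pair of compound 2 and compound 4 is resolved at this position. Nothing available here accounts for the difference between 4-ethylphenyl and phenethyl.

The compounds shown leave open whether benzyl or a longer chain such as 3-phenylpropyl on the sulfur would read closer to phenethyl or to 4-ethylphenyl, and whether a phenyl ring carrying an amine or a carboxylic acid would read apart from all of them. With a single concentration in one cell line, they also leave open whether the step between compound 2 and compound 4 would persist at other concentrations or in other cells.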